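Removing the Fluorine from the Sulfonyl Aryl Group

A few compounds are considered here, and "the series" means these few. Any claim that something is new, unique, unknown or untested is made for them only; others in the source may bear on it.

Compound 1 `Cc1ccc(F)cc1S(=O)(=O)N1CCN(c2ccc(C(=O)NCc3ccc(F)cc3)nn2)CC1` carries a (5-fluoro-2-methylphenyl)sulfonyl group on the shared core. In an ADME assay on microsomes from liver (Mus musculus), read by LC-MS, using NADPH, tested at 10 uM (a higher number here means that the liver removes a larger share of the compound in one pass, a lower number that the liver removes a smaller share), compound 1 gives 0.47, the lowest of the three numbers at hand. Compound 2 `O=C(NCc1ccccc1)c1ccc(N2CCN(S(=O)(=O)c3cccc(Cl)c3Cl)CC2)nn1` gives 0.81 in this assay, a number beyond the scatter above that of compound 1, and compound 3 `Cc1ccccc1S(=O)(=O)N1CC2(CN(c3ccc(C(=O)NCc4ccc(F)cc4)nn3)C2)C1` gives 0.98, the furthest from compound 1 and again beyond the scatter. No pair among these three compounds differs in only one place, so none of the gaps can be tied to a single change.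

Compound 4 `Cc1ccccc1S(=O)(=O)N1CCN(c2ccc(C(=O)NCc3ccc(F)cc3)nn2)CC1` is the unmeasured partner of compound 1. The difference between them is hydrogen in place of fluoro on an aromatic carbon, taking the group from (5-fluoro-2-methylphenyl)sulfonyl to (2-methylphenyl)sulfonyl. For the measured compounds named here, nothing among the measured compounds shows what this change alone does to the extraction ratio. Since compound 2 with 0.81 and compound 3 with 0.98 lie well above compound 1, the expectation for compound 4 is a modest step upward that stays within the usual scatter, a number 0.080 higher from compound 1 to compound 4 (within the scatter). The estimate for compound 4 in this assay is 0.55, with a range from 0.4 to 0.75.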

Compound 4, hepatic extraction ratio: 0.7
Compound 4: the middle estimate sits 0.15 below what was measured; measured number inside the range.
By their numbers in this assay, from the lowest: compound 1; then compound 4; then compound 2; then compound 3.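

In this assay, replacing fluoro with hydrogen on an aromatic carbon, meta to a large group and para to a methyl group, gives a number 0.23 higher from compound 1 to compound 4 (beyond the scatter). For the compounds shown here, this is the first reading of a single change, and it shows that this one position, where a single heavy atom leaves and no ring or net charge is involved, can on its own move the hepatic extraction ratio by more than repeated measurements would scatter, with the fluoro form holding the lower number. Nothing at hand speaks to the reason for this step.

From the compounds shown here alone, whether the step belongs to fluoro in particular remains open, since a chloro, methoxy or nitrile group at the same carbon could show whether other groups hold the extraction ratio down in the same way or leave it nearer the level of the hydrogen form. Also open, going by these compounds, is whether the same exchange gives a step of like size at another carbon of that ring or on a different core.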